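This account rests on a few compounds, and the source may have more. Where it says the series, first, only, none or still open, it means among the compounds named here.

Series notes. In a functional assay on BGC-823 cells (Homo sapiens) for cytotoxicity, read by MTT assay, with a stated time of 48 h (a higher number here means a weaker inhibitor, a lower number a stronger inhibitor), compound 2 `Clc1ccnc2cc(OCc3ccccc3)ccc12` gives 5170 nM, the highest of the three numbers, yet compound 1 `CCCCOc1ccc2c(Cl)ccnc2c1` at 3610 nM and compound 3 `Fc1ccc(COc2ccc3c(Cl)ccnc3c2)cc1` at 2780 nM both sit within the scatter of it. Compound 4 `C=CCOc1ccc2c(Cl)ccnc2c1` differs from compound 2 by vinyl in place of phenyl on a saturated chain carbon bound to an oxygen on an aromatic ring. The step that bears on this is the one where phenyl replaced propyl at the same place, a 1.4-fold higher number from compound 1 to compound 2 (0.16 log units; within the scatter); the other measured step, a 1.9-fold lower number from compound 2 to compound 3 (0.27 log units; within the scatter), also stayed within the scatter. Going back from phenyl to a vinyl chain is therefore expected to move this assay by no more than the scatter, in no firm direction. For compound 4 the expected value in this assay is 4000 nM, range 1800 nM to 9000 nM, the expected step being a 1.3-fold lower number from compound 2 to compound 4 (0.11 log units; within the scatter).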

Compound 4, half-maximal inhibitory concentration: 2930 nM
Compound 4: middle estimate off by 1.4-fold (0.14 log units), on the high side; measured number inside the range.
By their numbers in this assay, from the lowest: compounds 3, 4, 1 and 2 (each within the scatter of the next).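

In this assay vinyl in place of phenyl on a saturated chain carbon bound to an oxygen on an aromatic ring gives a 1.8-fold lower number from compound 2 to compound 4 (0.25 log units; within the scatter) and vinyl in place of propyl gives a 1.2-fold lower number from compound 1 to compound 4 (0.09 log units; within the scatter). For the compounds shown here, this place has now carried propyl, phenyl and vinyl, and no step among them leaves the scatter, so the aromatic ring and the double bond show no firm effect here. Nothing available explains these numbers. On these data alone, whether an amine or a carboxylic acid at this place would give a step beyond the scatter in this assay remains open.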